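A few compounds are considered here, and "the series" means these few. Any claim that something is new, unique, unknown or untested is made for them only; others in the source may bear on it.

Compound 1 `COc1cc(NCc2ccc(Cl)cc2)cc(OC)c1OC`: > 80000 nM
Compound 2 `COc1ccc(CN(C(=O)CO)c2cc(OC)c(OC)c(OC)c2)cc1O`: 370 nM

In a functional assay on KYSE-450 cells (Homo sapiens) for inhibition, read by MTT assay, with a stated time of 48 h (a lower number here means a stronger inhibitor, a higher number a weaker inhibitor), compound 1 reads > 80000 nM, which is a limit of the assay and not a number. Going by the values given here, compound 2 gives 370 nM, the only true number so far in this assay. Compound 3 `COc1ccc(CN(C(=O)C2CC2)c2cc(OC)c(OC)c(OC)c2)cc1O` has cyclopropyl in place of hydroxymethyl on a carbonyl carbon. Among the compounds with values here, no measured pair of compounds shows what this change does. The expected change a 1.2-fold lower number from compound 2 to compound 3 (0.09 log units; within the scatter) is small, with no firm direction and probably nothing beyond the usual scatter. Compound 3 is estimated at 300 nM, with an expected range of 60 nM to 1500 nM.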

Compound 3, half-maximal inhibitory concentration: 80 nM
The estimate for compound 3 lay 3.8-fold (0.57 log units) above the measured number, within the range that was stated.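

Replacing hydroxymethyl with cyclopropyl on the carbonyl carbon gives a 4.6-fold lower number from compound 2 to compound 3 (0.67 log units; beyond the scatter) in this assay. Going by these compounds alone, this is the first measured sign that the group at this place changes the reading, and it shows that hydroxymethyl is not required for a low number. Nothing measured here explains why the number falls.

A single step cannot separate the effect of gaining the cyclopropyl ring from that of losing hydroxymethyl. On these data alone, how an amine or a longer carbon chain would read at this place remains open.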